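The source may hold more compounds than are shown below. What is called first, only, known or untested is meant among the compounds shown, and "the series" means these compounds.

So far two compounds built on the same core have been tested in a functional assay (trachea) with Cavia porcellus as the target; a higher number here means a weaker inhibitor, a lower number a stronger inhibitor. Compound 1 `C=CCn1nc(-c2cccnc2)c2ccccc2c1=O` gives 2140 nM, and compound 2 `O=c1c2ccccc2c(-c2cccnc2)nn1C1CCCC1` gives 2750 nM. Compound 2 therefore stands within the scatter of compound 1, and the two cannot be told apart on these numbers. Among the compounds with values here, compound 3 `O=c1c2ccccc2c(-c2cccnc2)nn1CC1CCCCC1` is altered at the same site as the only change seen so far: cyclohexylmethyl in place of cyclopentyl on an aromatic nitrogen, (cyclohexylmethyl in place of cyclopentyl on an aromatic nitrogen). Within the data shown here, the one measured step that bears on this is a 1.3-fold higher number from compound 1 to compound 2 (0.11 log units; within the scatter), a swap of one carbon group for another on that nitrogen. A single small step is thin evidence, but it gives no reason to expect a real shift in either direction. The expected step is a 1.1-fold lower number from compound 2 to compound 3 (0.04 log units; within the scatter), which means no change beyond the scatter. Compound 3 is estimated at 2500 nM, with an expected range of 1000 nM to 6000 nM.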

Compound 3, half-maximal inhibitory concentration: 209 nM
Estimate against measurement, compound 3: 12-fold (1.08 log units) above, and the stated range ends above it.
By their numbers in this assay, from the lowest: compound 3; then compounds 1 and 2 (each within the scatter of the next).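

Within the data shown here, the nitrogen substituent can matter a great deal: allyl and cyclopentyl could not be told apart, yet (this assay) cyclohexylmethyl in place of cyclopentyl gives a 13-fold lower number from compound 2 to compound 3 (1.12 log units; beyond the scatter) and is the first change to stand clear of the scatter. Seen from compound 1, cyclohexyl in place of vinyl on the saturated chain carbon bound to the aromatic nitrogen gives a 10-fold lower number from compound 1 to compound 3 (1.01 log units; beyond the scatter) on the same shared core, so both large steps end at compound 3. Nothing available explains why this group does so much better.

Because compound 3 differs from compound 2 in both ring size and the added chain carbon, the compounds shown cannot say which of these matters. Also open, on these data alone, is how cyclohexyl placed directly on the nitrogen, a longer chain ending in cyclohexyl, or a phenyl ring or an amine at this position would behave.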